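The compounds below may be only part of what the source reports. "The series", "measured", "known", "first", "only" and "open" are said of these compounds alone.

Of the compounds shown here, two built on a shared core have been tested so far in an assay for binding affinity to E3 ubiquitin-protein ligase Mdm2 (Homo sapiens), read by fluorescence polarization, with a stated time of 15 min; a lower number here means a stronger inhibitor, a higher number a weaker inhibitor. Compound 1 `CCOC(=O)c1[nH]c2cc(Cl)ccc2c1C(NCC1CCCCC1)c1nnnn1-c1ccc(Cl)cc1` gives 117000 nM in this assay, which marks it as a very weak inhibitor. Compound 2 `CCOC(=O)c1[nH]c2cc(Cl)ccc2c1C(NCC1CCCCC1)c1nnnn1-c1ccc(OCc2c(Cl)cccc2Cl)cc1` was reported as "not active" (no number reported) in this assay, and no number was recorded for it, so where it stands can only be said in words: it showed no measurable binding under the conditions used.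

Compound 3 `CCOC(=O)c1[nH]c2cc(Cl)ccc2c1C(NCC1CCCCC1)c1nnnn1-c1ccc(OCc2ccc(Br)cc2)cc1` is the next compound in line. It differs from compound 2 in a single place: 4-bromophenyl in place of 2,6-dichlorophenyl on a saturated chain carbon bound to an oxygen on an aromatic ring. Within the data shown here, no measured pair in this set shows what such a change does, so the size of the step from compound 2 to compound 3 in this assay cannot be read from existing data. Given that compound 2 showed no activity and compound 1, the only compound with a number, is itself very weak, the expectation is for no change beyond the usual scatter, with compound 3 remaining weak.

Compound 3 is therefore expected to give about 150000 nM in this assay, in a range from 50000 nM to 500000 nM.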

Compound 3, inhibition constant: "not active" (no number reported)
Compound 3 has no reported number here; the estimate stays without a comparison.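

Among these compounds, compound 2 and compound 3 both lack a number in this assay, so no step between them can be read. No supporting data bear on this result. The compounds shown leave open whether replacing 2,6-dichlorobenzyl with 4-bromobenzyl changes binding strength at all, as any difference would lie out of reach of this assay's reported numbers.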